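From difluoro to dichloro on the sulfonyl sulfur

The source may report more compounds than this note shows. Statements on the series, on what has been measured and on what is new or still open speak of the compounds shown alone.

Of the compounds shown here, two have been measured in an ADME assay on microsomes from liver (Homo sapiens) for metabolic stability, tested at 2.5 uM; a higher number here means faster removal of the compound, a lower number slower removal. Compound 1 `O=S(=O)(c1cc(Cl)cc(Cl)c1)c1cnc2c(F)cccc2c1-c1cccc(Cl)c1` gives 1.2 mL/min. Compound 2 `COc1cccc(-c2c(S(=O)(=O)c3cc(F)cc(F)c3)cnc3c(F)cccc23)c1` gives 2.76 mL/min, the higher of the two numbers; the gap between compound 2 and compound 1 lies beyond the usual scatter of repeated measurements, so compound 2 is removed faster than compound 1.

Compound 3 `COc1cccc(-c2c(S(=O)(=O)c3cc(Cl)cc(Cl)c3)cnc3c(F)cccc23)c1` has not yet been measured in this assay. It differs from compound 2 in one place: 3,5-dichlorophenyl in place of 3,5-difluorophenyl on a sulfonyl sulfur. Within the data shown here, no measured pair in the set shows this change on its own, so its effect cannot be read directly from the data. Among the measured compounds shown here, the only other compound carrying a 3,5-dichlorophenyl on the sulfonyl sulfur is compound 1, which also differs elsewhere and gives 1.2 mL/min.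

Taking the two measured values together, the expectation for the step from compound 2 to compound 3 is a 1.4-fold lower number from compound 2 to compound 3 (0.14 log units; within the scatter), a modest move toward slower removal that may still fall within the scatter. On that basis compound 3 is estimated at 2 mL/min, with a range from 1 mL/min to 4 mL/min.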

Compound 3, intrinsic clearance in a liver preparation (reported as CLH), per the amount of preparation that the assay uses: 2.31 mL/min
Beside the measured number, compound 3's estimate is 1.2-fold (0.06 log units) below it; the range from low to high includes it.
By their numbers in this assay, from the lowest: compounds 1, 3 and 2 (each within the scatter of the next, the first and the last beyond it).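

Among these compounds, with this result, the change from 3,5-difluorophenyl to 3,5-dichlorophenyl on a sulfonyl sulfur can be read on its own for the first time, and in this assay it gives a 1.2-fold lower number from compound 2 to compound 3 (0.08 log units; within the scatter), so this pair of compounds does not separate the two halogens at this position. The same result also isolates a second change, methoxy in place of chloro on an aromatic carbon, which gives a 1.9-fold higher number from compound 1 to compound 3 (0.28 log units; within the scatter), so neither single change shown here lies beyond the scatter, although that second step is the larger of the two. Nothing among the data shown speaks to why these numbers stand where they do.

On these data alone, whether the two changes would act the same way in other combinations stays open, and a compound joining chloro on the aromatic carbon with 3,5-difluorophenyl on the sulfonyl sulfur would test this. As far as these compounds go, it is also open how the number would respond to a sulfonyl group carrying an unsubstituted phenyl or a pyridine ring, or to an amine or a carboxylic acid in place of the methoxy group.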